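Removing the Cyclopentyl Group from an Amide in Kinase Inhibitors

A few compounds are considered here, and "the series" means these few. Any claim that something is new, unique, unknown or untested is made for them only; others in the source may bear on it.

Compound 2 `CCC1C(=O)N(C)c2cnc(-n3ccc4cc(C(=O)NC5CCCC5)ccc43)nc2N1c1ccn(C)n1` is one of two close analogues tested in an assay for inhibition of serine/threonine-protein kinase PLK2 (Homo sapiens), read by FRET and Z'-LYTE, with a stated time of 1 h (a higher number here means a weaker inhibitor, a lower number a stronger inhibitor), where compound 2 gives 90.9 nM. Its partner, compound 1 `CCC1C(=O)N(C)c2cnc(-n3ccc4cc(C(=O)NCC(C)C)ccc43)nc2N1c1ccn(C)n1`, gives 159 nM in this assay, and the step of a 1.7-fold lower number from compound 1 to compound 2 (0.24 log units; within the scatter) shows that exchanging isobutyl for cyclopentyl on the amide-type nitrogen changed little. Compound 3 `CCC1C(=O)N(C)c2cnc(-n3ccc4cc(C(N)=O)ccc43)nc2N1c1ccn(C)n1` goes further: the change is hydrogen in place of cyclopentyl on an amide-type nitrogen, leaving a plain carbamoyl group. Among the compounds with values here, no measured step covers loss of the whole substituent on this nitrogen, so the only step at hand, a 1.7-fold lower number from compound 1 to compound 2 (0.24 log units; within the scatter), bears on it just loosely, indicating that two similar carbon groups there give similar numbers. Stripping the group away entirely is a larger alteration, and a somewhat weaker result is expected, with wide uncertainty. The expected step is a 2.8-fold higher number from compound 2 to compound 3 (0.44 log units; beyond the scatter). Compound 3 is estimated at 250 nM, within a range from 80 nM to 800 nM.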

Compound 3, half-maximal inhibitory concentration: 384 nM
Compound 3: middle estimate off by 1.5-fold (0.19 log units), on the low side; the range from low to high includes it.
By their numbers in this assay, from the lowest: compounds 2 and 1 (each within the scatter of the next); then compound 3.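

On the amide-type nitrogen, replacing the cyclopentyl with hydrogen gives a 4.2-fold higher number from compound 2 to compound 3 (0.63 log units; beyond the scatter) and replacing the isobutyl with hydrogen gives a 2.4-fold higher number from compound 1 to compound 3 (0.38 log units; beyond the scatter) in this assay. Within the data shown here, the earlier pair showed only that two carbon groups on this nitrogen read alike, whereas these modest steps show that having such a group at all goes with a lower number than the plain carbamoyl group. No measurement at hand explains this difference.

The compounds shown leave open how the number changes with a group as small as methyl on this nitrogen. They also leave open whether a longer chain, or a chain ending in an amine or a carboxylic acid, would give a number lower than those of compound 1 and compound 2.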